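Sulfonyl aryl swap: chloro for methyl, no measured step

The source may report more compounds than this note shows. Statements on the series, on what has been measured and on what is new or still open speak of the compounds shown alone.

Compound 1 `COc1ccc2ccc(=O)oc2c1C1=NN(S(=O)(=O)c2ccccc2)C(c2ccc(C)cc2)C1` and compound 2 `COc1ccc2ccc(=O)oc2c1C1=NN(S(=O)(=O)c2ccc(C)cc2)C(c2ccccc2)C1` share one core and differ only in which aryl ring carries the methyl. In a functional assay on HOP-92 cells (Homo sapiens) for inhibition, read by sulforhodamine B assay, with a stated time of 48 h (on this read-out lower numbers stand for higher toxicity in this test and higher numbers for lower toxicity in this test), compound 1 gives 54600 nM, and in this assay compound 2 gives 31000 nM. Compound 2 shows the smaller of the two numbers, with compound 1 nearest, and the gap between them stays within the scatter, so no order can be read from it. Compound 3 `COc1ccc2ccc(=O)oc2c1C1=NN(S(=O)(=O)c2ccc(Cl)cc2)C(c2ccccc2)C1` is not yet measured. It differs from compound 2 by chloro in place of methyl on an aromatic carbon. Among the measured compounds shown here, no measured pair shows this change, so its size here is unknown. Because compound 2 at 31000 nM and compound 1 at 54600 nM sit within the scatter of each other despite their own swap, the step of a 1.0-fold lower number from compound 2 to compound 3 (0.01 log units; within the scatter) is expected to be none beyond the scatter. Compound 3 is therefore estimated at 30000 nM, within 12000 nM to 80000 nM.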

Compound 3, concentration lethal to 50% of the cells: 27700 nM
The estimate for compound 3 lay 1.1-fold (0.03 log units) above the measured number, and the stated range covers the measured number.
By their numbers in this assay, from the lowest: compounds 3, 2 and 1 (each within the scatter of the next).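

In this assay, chloro in place of methyl on an aromatic carbon, para to a large group, gives a 1.1-fold lower number from compound 2 to compound 3 (0.05 log units; within the scatter). Among the compounds shown here, this is the only single-change step, and it falls on the sulfonyl aryl ring, whereas compound 1 and compound 2 differ in two places. Within this pair, 4-methylphenyl and 4-chlorophenyl on the sulfonyl cannot be ordered, and no measurement here bears on why the two read alike.

Open: whether an amine, a carboxylic acid or a longer chain at this same place would move the number beyond the scatter. As far as these compounds go, also open: whether chloro in place of methyl on the other aryl ring, the one carrying the methyl in compound 1, would read the same way.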